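This account rests on a few compounds, and the source may have more. Where it says the series, first, only, none or still open, it means among the compounds named here.

Three compounds sharing one core have been run through a functional assay on MCF7 cells (Homo sapiens) for cytotoxicity, read by MTT assay, with a stated time of 72 h; on this read-out higher numbers stand for weaker inhibition and lower numbers for stronger inhibition. Compound 1 `NC(=O)N1CCN(C(=S)SCc2cn(Cc3ccccc3F)nn2)CC1` reaches only a limit of the assay there, > 128000 nM. Compound 2 `CC(C)NC(=O)N1CCN(C(=S)SCc2cn(Cc3ccccc3F)nn2)CC1` gives 1860 nM, and compound 3 `NC(=O)N1CCN(C(=S)SCc2cn(Cc3ccc(F)cc3)nn2)CC1` gives 22100 nM, the higher of the two plain numbers recorded. Compound 4 `O=C(NC1CCCCC1)N1CCN(C(=S)SCc2cn(Cc3ccc(F)cc3)nn2)CC1` has not yet been measured; it differs from compound 3 by cyclohexyl in place of hydrogen on an amide-type nitrogen. The measured step that bears on this is an at least 68-fold lower number from compound 1 to compound 2 (1.83 log units; beyond the scatter), where hydrogen on the same amide-type nitrogen gave way to isopropyl; the other step, an at least 5.7-fold lower number from compound 1 to compound 3 (0.76 log units; beyond the scatter), changes a different part of the molecule. A large fall in the number is therefore expected, a 37-fold lower number from compound 3 to compound 4 (1.57 log units; beyond the scatter). Compound 4 is estimated at 600 nM, within 150 nM to 2500 nM.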

Compound 4, half-maximal inhibitory concentration: > 128000 nM
Compound 4: a limit, no number (the forecaster's own chance of this, stated with the estimate: 3%); middle value at least 210-fold (2.32 log units) from the limit.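

At the amide-type nitrogen, a larger group does not always lower the number in this assay: cyclohexyl in place of hydrogen gives an at least 5.7-fold higher number from compound 3 to compound 4 (0.76 log units; beyond the scatter), against the direction of isopropyl in an at least 68-fold lower number from compound 1 to compound 2 (1.83 log units; beyond the scatter). These two steps differ in both the entering group and the fluorophenyl group present, so the reversal cannot be assigned to either alone. Compound 4 sits at a limit, not a plain number: the limit of > 128000 nM in this assay, at which 2 of the 4 values shown sit.

Going by these compounds, what isopropyl does with the 4-fluorophenyl group, or cyclohexyl with the 2-fluorophenyl group, remains open. So does the effect of a cyclopentyl group or a longer chain on this nitrogen.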